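Cytotoxicity outlook for a thiazolyl-pyrrolidinone analogue of compound 1

The compounds below may be only part of what the source reports. "The series", "measured", "known", "first", "only" and "open" are said of these compounds alone.

compound 1 `O=C(Nc1cc(F)c(F)c(F)c1)N1Cc2c(-c3ccc(F)cc3F)cnn2CC1C1CC1`: 32100 nM
compound 2 `O=C(Nc1cc(F)c(F)c(F)c1)N1CCCn2ncc(N3CC(c4ccccc4)CC3=O)c2C1`: > 2000 nM
compound 3 `C[C@H]1Cn2ncc(N3CC(c4ccccc4)CC3=O)c2CN1CC(=O)Nc1cc(F)c(F)c(F)c1`: > 2000 nM

For the measured compounds named here, in a toxicity assay on HepG2 2.2.15 cells (Homo sapiens) for cytotoxicity, read by CellTiter-Glo (a lower number here means that less compound is tolerated, a higher number that more compound is tolerated), compound 1 gives 32100 nM, the only value that is a number. For compound 2 this assay reports only a limit, > 2000 nM. For compound 3 as well this assay reports only a limit, > 2000 nM; two of the three values therefore sit at the limit of > 2000 nM in this assay, at which 2 of the 3 values shown sit. Compound 4 `Cc1cnc(C2CC(=O)N(c3cnn4c3CN(C(=O)Nc3cc(F)c(F)c(F)c3)C(C3CC3)C4)C2)s1` has not yet been measured. It differs from compound 1 in one place: 4-(5-methyl-1,3-thiazol-2-yl)-2-oxopyrrolidin-1-yl in place of 2,4-difluorophenyl on an aromatic carbon. Going by the values given here, no measured pair here tracks this kind of change, so the size of the step is an estimate; compound 4 is expected to stay within the usual scatter of compound 1, with a 1.1-fold lower number from compound 1 to compound 4 (0.03 log units; within the scatter). Compound 4 is estimated at 30000 nM in this assay, with a range from 8000 nM to 100000 nM.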

Compound 4, half-maximal cytotoxic concentration: 96200 nM
For compound 4 the middle estimate is 3.2-fold (0.51 log units) below the measured one; the range from low to high includes it.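

In this assay, for the compounds shown here, 4-(5-methyl-1,3-thiazol-2-yl)-2-oxopyrrolidin-1-yl in place of 2,4-difluorophenyl on this aromatic carbon gives a 3.0-fold higher number from compound 1 to compound 4 (0.48 log units; beyond the scatter), the first readable step at this position. Compound 2 and compound 3 give only limits, so neither offers a step: the limit of > 2000 nM in this assay, at which 2 of the 4 values shown sit. No measurement shown gives a cause for this step.

Going by these compounds, whether the step comes from the thiazole or from the pyrrolidinone remains open. So does how a morpholine or a carboxylic acid at this position would read.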